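The source may report more compounds than this note shows. Statements on the series, on what has been measured and on what is new or still open speak of the compounds shown alone.

Measured so far in an ADME assay on MT4 cells (Homo sapiens) for cytotoxicity, read by MTT assay, with a stated time of 4 days; on this read-out lower numbers stand for higher toxicity in this test and higher numbers for lower toxicity in this test:
compound 1 `Cc1ccc(-c2c(C)c(-c3ccc4c(c3C)CCCO4)c(C(OC(C)(C)C)C(=O)O)c(C)c2NS(C)(=O)=O)cc1C` gives 24000 nM
compound 2 `Cc1ccc(-c2c(C)c(-c3ccc(C)c(C)c3)c(C(OC(C)(C)C)C(=O)O)c(C)c2NS(C)(=O)=O)cc1C` gives 15000 nM
compound 3 `Cc1ccc(-c2c(C)c(-c3ccc(Cl)c(F)c3)c(C(OC(C)(C)C)C(=O)O)c(C)c2NS(C)(=O)=O)cc1C` gives 22000 nM

Compound 2 at 15000 nM does not separate from compound 1 or compound 3. The measured steps are a 1.6-fold lower number from compound 1 to compound 2 (0.20 log units; within the scatter) and a 1.5-fold higher number from compound 2 to compound 3 (0.17 log units; within the scatter) and also a 1.1-fold lower number from compound 1 to compound 3 (0.04 log units; within the scatter) in this set, all within the scatter.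

Compound 4 `Cc1ccc(-c2c(C)c(-c3ccc(C)c(C)c3)c(C(OC(C)(C)C)C(=O)O)c(C)c2NS(=O)(=O)C2CC2)cc1C` differs from compound 2 at one place only: cyclopropyl in place of methyl on a sulfonyl sulfur.

For the measured compounds named here, none of the measured steps touches the sulfonyl sulfur. All three exchange the aromatic group on the shared core, so they bear on this change only indirectly. They show that the read-out stays flat across these three compounds and say nothing direct about the new group. With no measurement at this place, no step beyond the scatter is expected in this assay for now. The expected step is no change at the digits printed from compound 2 to compound 4 (within the scatter) and it rests on thin evidence. Compound 4 is estimated at 15000 nM with an expected range from 7000 nM to 32000 nM as the working figure.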

Compound 4, half-maximal cytotoxic concentration: 11000 nM
The estimate for compound 4 lay 1.4-fold (0.13 log units) above the measured number, and the stated range covers the measured number.
By their numbers in this assay, from the lowest: compounds 4, 2, 3 and 1 (each within the scatter of the next, the first and the last beyond it).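

In this assay, for the compounds shown here, cyclopropyl in place of methyl on the sulfonyl sulfur gives a 1.4-fold lower number from compound 2 to compound 4 (0.13 log units; within the scatter), the first direct reading at this place. The earlier compounds shown here exchanged only the aromatic group on the shared core, so the flat read-out they showed now extends to one change at a second place, with the sulfonamide nitrogen and the rest of compound 2 unchanged. No other data bear on this step, and the result therefore stands as an observation with no explanation attached.

Only methyl and cyclopropyl are shown on the sulfonyl sulfur, so it stays open whether a longer chain such as n-butyl, an unsubstituted phenyl ring or a dimethylamino group there would also keep the read-out within the scatter. Also open, as far as these compounds go, is whether the cyclopropyl exchange gives the same result when the core carries 4-chloro-3-fluorophenyl, as in compound 3, in place of 3,4-dimethylphenyl on the aromatic carbon.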